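Aminophenyl enone pyrazoles: dropping one methoxy group

The source may report more compounds than this note shows. Statements on the series, on what has been measured and on what is new or still open speak of the compounds shown alone.

Working notes on a pair of chalcone-like enones sharing an aminophenyl ketone and a pyrazole core. The read-out is a functional assay on MCF7 cells (Homo sapiens) for inhibition, read by MTT assay, with a stated time of 48 h; on this read-out lower numbers stand for stronger inhibition and higher numbers for weaker inhibition. Compound 1 `COc1ccc(-c2cc(/C=C/C(=O)c3ccc(N)cc3)[nH]n2)cc1` carries a single methoxy on its pendant phenyl; in this assay compound 1 gives 800 nM. Compound 2 `COc1cc(-c2cc(/C=C/C(=O)c3ccc(N)cc3)[nH]n2)cc(OC)c1OC` carries three methoxy groups on that phenyl; in this assay compound 2 gives 1600 nM. Within the data shown here, only these two numbers exist so far, and the two compounds differ in more than one place, so no single-point step is available between them; the gap between them lies within the scatter of the measurement, so the two values cannot be told apart.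

Compound 3 `COc1ccc(-c2cc(/C=C/C(=O)c3ccc(N)cc3)[nH]n2)cc1OC` is the dimethoxy analog. It differs from compound 2 by hydrogen in place of methoxy on an aromatic carbon, in words hydrogen in place of methoxy on an aromatic carbon. With the mono- and trimethoxy compounds indistinguishable, the expected step from compound 2 to compound 3 is a 1.5-fold lower number from compound 2 to compound 3 (0.16 log units; within the scatter), none beyond the scatter. For compound 3 the estimate in this assay is 1100 nM, with a range from 400 nM to 3000 nM.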

Compound 3, half-maximal inhibitory concentration: 1900 nM
Compound 3: middle estimate off by 1.7-fold (0.24 log units), on the low side; measured number inside the range.
By their numbers in this assay, from the lowest: compounds 1, 2 and 3 (each within the scatter of the next, the first and the last beyond it).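

In this assay, hydrogen in place of methoxy on this aromatic carbon, ortho to a methoxy group and meta to a large group, gives a 1.2-fold higher number from compound 2 to compound 3 (0.07 log units; within the scatter), so this methoxy of compound 2 can go without a readable change. Among these compounds, the dimethoxy analog also supplies the first single-place comparison with the monomethoxy compound: methoxy in place of hydrogen on an aromatic carbon gives a 2.4-fold higher number from compound 1 to compound 3 (0.38 log units; beyond the scatter), a modest loss of inhibition. Among these three compounds, the one step beyond the scatter is therefore the one from the monomethoxy to the dimethoxy pattern, while the step between the dimethoxy and trimethoxy patterns cannot be read as a change.

Still open, going by these compounds, is whether a fluorine, a hydroxyl or an ethoxy on this aromatic carbon would behave like hydrogen or like methoxy, and whether the modest step would hold up on repeated measurement, given how close it lies to the scatter. Nothing at hand accounts for either step.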